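Compound 2 to compound 4: trifluoromethyl for chloro

The source may report more compounds than this note shows. Statements on the series, on what has been measured and on what is new or still open speak of the compounds shown alone.

For the measured compounds named here, the series so far holds compound 1 (`O=C(/C=C/c1ccc(O)c(O)c1)N1CCN(c2ccccc2Cl)CC1`), compound 2 (`O=C(/C=C/c1ccc(O)c(O)c1)N1CCN(c2cccc(Cl)c2)CC1`) and compound 3 (`COc1ccc(N2CCN(C(=O)/C=C/c3ccc(O)c(O)c3)CC2)cc1`). In a functional assay on MCF7 cells (Homo sapiens) for antiproliferative activity, read by MTT assay, with a stated time of 48 h (on this read-out lower numbers stand for stronger inhibition and higher numbers for weaker inhibition), compound 2 gives 1.34 ug/mL, within the scatter of compound 1 at 1.36 ug/mL, and compound 3 gives 0.52 ug/mL. Compound 2 therefore sits with compound 1 at the upper end of the three numbers. The next compound is compound 4 (`O=C(/C=C/c1ccc(O)c(O)c1)N1CCN(c2cccc(C(F)(F)F)c2)CC1`). The change is trifluoromethyl in place of chloro on an aromatic carbon, meta to a large group.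

Going by the values given here, no measured step makes this exchange, so the evidence is indirect. The two chlorophenyl compounds show a 1.0-fold lower number from compound 1 to compound 2 (0.01 log units; within the scatter). The methoxyphenyl compound is the only one apart, with a 2.6-fold lower number from compound 2 to compound 3 (0.41 log units; beyond the scatter) and a 2.6-fold lower number from compound 1 to compound 3 (0.42 log units; beyond the scatter), both modest. On this basis no step beyond the scatter is expected, and the estimated step is a 1.1-fold lower number from compound 2 to compound 4 (0.05 log units; within the scatter). For compound 4 the estimated value is 1.2 ug/mL, with an expected range of 0.5 ug/mL to 2.8 ug/mL.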

Compound 4, half-maximal inhibitory concentration: 1.24 ug/mL
Beside the measured number, compound 4's estimate is 1.0-fold (0.01 log units) below it, and the stated range covers the measured number.
By their numbers in this assay, from the lowest: compound 3; then compounds 4, 2 and 1 (each within the scatter of the next).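

In this assay the exchange gives a 1.1-fold lower number from compound 2 to compound 4 (0.03 log units; within the scatter) and so does not separate trifluoromethyl from chloro on this aromatic carbon, meta to a large group. Among the earlier compounds this place carried only chloro; it now also carries a group of 4 heavy atoms in place of 1 with no step beyond the scatter. No measured property of either group accompanies this result, so the data offer no account of it.

As far as these compounds go, whether an amine or a carboxylic acid on this aromatic carbon would give a step beyond the scatter stays open. Also open is how trifluoromethyl behaves elsewhere on this aromatic ring, as the compounds shown hold it at this one place only.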